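A few compounds are considered here, and "the series" means these few. Any claim that something is new, unique, unknown or untested is made for them only; others in the source may bear on it.

Three of the compounds share a core in which a sulfoxide joins a fluorinated chain to an amide that sits on a carbon bearing three hydroxymethyl groups. Compound 1 `O=C(CC[S+]([O-])CCC(F)(F)C(F)(F)C(F)(F)C(F)(F)C(F)(F)C(F)(F)F)NC(CO)(CO)CO` carries the shorter fluorinated chain, and in an ADME assay for solubility (a higher number here means a more soluble compound, a lower number a less soluble compound), compound 1 gives 1200 ug/mL. Compound 2 `O=C(CC[S+]([O-])CCC(F)(F)C(F)(F)C(F)(F)C(F)(F)C(F)(F)C(F)(F)C(F)(F)C(F)(F)F)NC(CO)(CO)CO` carries the longer chain, and in this assay compound 2 gives 25 ug/mL. That change alone gives a 48-fold lower number from compound 1 to compound 2 (1.68 log units; beyond the scatter). Compound 2 thus stands at the lowest of the two numbers, with compound 1 as its nearest neighbour. Compound 3 `O=C(CC[S+]([O-])CCC(F)(F)C(F)(F)C(F)(F)C(F)(F)C(F)(F)C(F)(F)F)NC(CO[C@H]1O[C@@H](CO)[C@@H](O)[C@@H](O)[C@@H]1O)(CO[C@@H]1O[C@H](CO)[C@H](O)[C@H](O)[C@H]1O)CO[C@@H]1O[C@H](CO)[C@H](O)[C@H](O)[C@H]1O` has the shorter chain with a sugar on each of the three oxygens. In this assay compound 3 gives > 10000 ug/mL, which is a limit of the assay and not a number. It is the limit of > 10000 ug/mL in this assay, at which 1 of the 3 values shown sits.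

Compound 4 `O=C(CC[S+]([O-])CCC(F)(F)C(F)(F)C(F)(F)C(F)(F)C(F)(F)C(F)(F)C(F)(F)C(F)(F)F)NC(CO)(CO)COC1O[C@H](CO)[C@H](O)[C@H](O)[C@H]1O` differs from compound 2 by 3,4,5-trihydroxy-6-(hydroxymethyl)oxan-2-yl in place of hydrogen on an oxygen on a saturated carbon. Among the measured compounds shown here, no measured step covers this change directly; the only guide is that compound 1 and compound 3, which differ by three such sugars, lie far apart, with compound 3 at the top of what this assay reports. One sugar on the longer chain is therefore expected to raise the number substantially. The expected step is a 12-fold higher number from compound 2 to compound 4 (1.08 log units; beyond the scatter), upward and beyond the scatter. Compound 4 is estimated to give 300 ug/mL, within a range from 60 ug/mL to 1500 ug/mL.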

Compound 4, solubility: > 1500 ug/mL
Compound 4: only a limit was reported; the forecaster's own chance of this, stated with the estimate: 5%; at least 5.0-fold (0.69 log units) between middle value and limit.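

Among the compounds shown here, the step gives the first direct reading of this change: 3,4,5-trihydroxy-6-(hydroxymethyl)oxan-2-yl in place of hydrogen on an oxygen on a saturated carbon yields an at least 60-fold higher number from compound 2 to compound 4 (1.77 log units; beyond the scatter). In this assay compound 4 gives > 1500 ug/mL, which is a limit of the assay and not a number, so the step has a floor but no known upper end. Until now, sugars appeared only on the shorter chain and on all three oxygens together, whereas this pair shows that the low number of compound 2 is not fixed by its longer fluorinated chain, as a single sugar at this one position is enough to lift it by a large margin.

The compounds shown leave open how far the number of compound 4 really lies past its limit, and whether a second or third sugar on the longer chain would add anything that could be read in this assay. They also leave open whether a smaller group on the same oxygen, such as an amine or a carboxylic acid, would move the number as far, and what a still longer fluorinated chain would do.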